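From a methoxyphenyl to a fluorophenyl on the triazole

A few compounds are considered here, and "the series" means these few. Any claim that something is new, unique, unknown or untested is made for them only; others in the source may bear on it.

Compound 1 `CC1(C)[C@H]2CC[C@]1(C)N(Cc1cn(-c3ccccc3O)nn1)C(=O)C2` gives 90 nM in a functional assay on OVCAR-3 cells (Homo sapiens) for inhibition, read by MTT assay, with a stated time of 24 h; a lower number here means a stronger inhibitor, a higher number a weaker inhibitor.
Compound 2 `COc1ccc(-n2cc(CN3C(=O)C[C@@H]4CC[C@@]3(C)C4(C)C)nn2)cc1` gives 250 nM in this assay.
Compound 3 `CC1(C)[C@H]2CC[C@]1(C)N(Cc1cn(-c3ccccc3Br)nn1)C(=O)C2` gives 140 nM in this assay.

Among the three measured compounds, compound 2 has the highest number. Its nearest neighbour is compound 3, and that gap stays within the scatter: a 1.8-fold lower number from compound 2 to compound 3 (0.25 log units; within the scatter). The gap to compound 1 is the only one that reaches beyond the scatter: a 2.8-fold higher number from compound 1 to compound 2 (0.44 log units; beyond the scatter).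

Compound 4 `CC1(C)[C@H]2CC[C@]1(C)N(Cc1cn(-c3cccc(F)c3)nn1)C(=O)C2` has not been measured. It differs from compound 2 in one place: 3-fluorophenyl in place of 4-methoxyphenyl on an aromatic nitrogen.

All three measured steps concern the aryl group on the same ring nitrogen, so all three bear on this change. Their sizes were a 2.8-fold higher number from compound 1 to compound 2 (0.44 log units; beyond the scatter), a 1.8-fold lower number from compound 2 to compound 3 (0.25 log units; within the scatter) and a 1.6-fold higher number from compound 1 to compound 3 (0.19 log units; within the scatter). For the measured compounds named here, two of them stay within the scatter and one goes modestly beyond it, and none of the measured compounds carries a 3-fluorophenyl. Since compound 2 sits at the high end of the set and the other aryl groups gave lower numbers, compound 4 is expected to move toward a lower number, by a step that may or may not clear the scatter: a 1.6-fold lower number from compound 2 to compound 4 (0.19 log units; within the scatter).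

Compound 4 is therefore estimated at 160 nM in this assay, with a range from 70 nM to 400 nM.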

Compound 4, half-maximal inhibitory concentration: 430 nM
The estimate for compound 4 lay 2.7-fold (0.43 log units) below the measured number; the whole stated range lies below it.
By their numbers in this assay, from the lowest: compounds 1, 3, 2 and 4 (each within the scatter of the next, the first and the last beyond it).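

In this assay, the step of a 1.7-fold higher number from compound 2 to compound 4 (0.24 log units; within the scatter) leaves the 3-fluorophenyl and 4-methoxyphenyl groups on the aromatic nitrogen unseparated, so this exchange by itself gives no clear shift. The 3-fluorophenyl group does stand apart from the 2-bromophenyl and 2-hydroxyphenyl groups, with a 3.1-fold higher number from compound 3 to compound 4 (0.49 log units; beyond the scatter) and a 4.8-fold higher number from compound 1 to compound 4 (0.68 log units; beyond the scatter), the second being the largest step yet seen at this position, although compound 2 goes against any clean division of the aryl groups into two sets, as it lies within the scatter of both compound 3 and compound 4. Nothing among the data shown accounts for these differences.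

For the compounds shown here, the aryl groups in these compounds differ both in their substituent and in where it sits on the phenyl ring, so the contribution of each remains unresolved, as no two compounds carry the same substituent at different places. As far as these compounds go, how this assay would respond to a phenyl ring bearing an amine or a carboxylic acid, or to a longer chain in place of the aryl group on the aromatic nitrogen, also remains open.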